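Chain lengthening against cytotoxicity limits

The source may report more compounds than this note shows. Statements on the series, on what has been measured and on what is new or still open speak of the compounds shown alone.

In a functional assay on HEL cells (Homo sapiens) (on this read-out lower numbers stand for higher toxicity in this test and higher numbers for lower toxicity in this test), compound 1 (`CCCCCCc1cc2cn(C3CCC(CO)O3)c(=O)nc2o1`) stands only at a limit (> 143000 nM). Compound 2 (`CCCCCCCCc1cc2cn(C3CCC(CO)O3)c(=O)nc2o1`) likewise stands only at a limit (> 112000 nM). Going by the values given here, the single measured step (a step that the two limits leave unreadable from compound 1 to compound 2) therefore gives no size to carry forward. Compound 3 (`CCCCCCCCCCCCc1cc2cn(C3CCC(CO)O3)c(=O)nc2o1`) differs from compound 1 on the same chain (hexyl in place of hydrogen on a saturated chain carbon, six bonds along the chain from an aromatic carbon). No number has yet been read in this assay for this series, so any expectation is loose. A modest estimated step (an at least 1.5-fold lower number from compound 1 to compound 3 (0.20 log units; that floor lies within the scatter)) is expected towards higher toxicity. The expected value for compound 3 is 90000 nM with an estimated range (30000 nM to 200000 nM).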

Compound 3, half-maximal cytotoxic concentration: > 200000 nM
Compound 3 was reported as a limit (the forecaster's own chance of this, stated with the estimate: 70%); middle value at least 2.2-fold (0.34 log units) from the limit.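

In this assay, going by these compounds alone, compound 1, compound 2 and compound 3 all stand only at limits, so no step among them can be read. The compounds shown leave open whether lengthening the chain changes cytotoxicity at all.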